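The compounds below may be only part of what the source reports. "The series", "measured", "known", "first", "only" and "open" are said of these compounds alone.

Of the compounds shown here, three sharing one core have so far been measured in a functional assay on SW-620 cells (Homo sapiens) for cytotoxicity, read by MTT assay, with a stated time of 48 h; on this read-out lower numbers stand for stronger inhibition and higher numbers for weaker inhibition. Compound 1 `CCCCCCCCNC(=O)[C@@H](NC(=O)c1ccco1)[C@@H](C)O` gives 200000 nM. Compound 2 `CCCCCCCCCCCCNC(=O)[C@@H](NC(=O)c1ccco1)[C@@H](C)O` gives 87500 nM in this assay, and compound 3 `CCCCCCCCCCCCNC(=O)[C@@H](NC(=O)c1nccc2ccccc12)[C@@H](C)O` gives 65800 nM. Among these three numbers compound 2 stands second highest. The step of a 1.3-fold lower number from compound 2 to compound 3 (0.12 log units; within the scatter) lies within the usual scatter, whereas a 2.3-fold lower number from compound 1 to compound 2 (0.36 log units; beyond the scatter) lies beyond it.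

Compound 4 `CCCCCCCCCCCCNC(=O)[C@@H](NS(=O)(=O)c1ccc(C)cc1)[C@@H](C)O` has not yet been measured. It differs from compound 2 in one place: (4-methylphenyl)sulfonyl in place of (furan-2-yl)carbonyl on an amine nitrogen. For the measured compounds named here, of the two measured steps, only the one from compound 2 to compound 3 concerns the same part of the molecule, the group carried on that amine nitrogen, and that step, a 1.3-fold lower number from compound 2 to compound 3 (0.12 log units; within the scatter), stayed within the scatter. The other step, a 2.3-fold lower number from compound 1 to compound 2 (0.36 log units; beyond the scatter), concerns the chain, which compound 4 keeps unchanged, so it does not bear on the present change. On this evidence no step beyond the scatter in this assay is expected for compound 4, in either direction, with the proviso that a sulfonyl group at this position has not been tried before in this series. Compound 4 is therefore estimated at 80000 nM, with a range from 30000 nM to 200000 nM. This estimate corresponds to an expected step of a 1.1-fold lower number from compound 2 to compound 4 (0.04 log units; within the scatter).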

Compound 4, half-maximal inhibitory concentration: 25600 nM
Estimate against measurement, compound 4: 3.1-fold (0.49 log units) above, outside the stated range (below it).
By their numbers in this assay, from the lowest: compound 4; then compounds 3 and 2 (each within the scatter of the next); then compound 1.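

In this assay, for the compounds shown here, the group on the amine nitrogen proves able to move the number beyond the scatter (the step is a 3.4-fold lower number from compound 2 to compound 4 (0.53 log units; beyond the scatter)), which the only earlier change at this place did not show (there the step was a 1.3-fold lower number from compound 2 to compound 3 (0.12 log units; within the scatter)). This place is therefore not indifferent to what it carries: (4-methylphenyl)sulfonyl, with its sulfur and its six-membered aromatic ring of carbon only, gives a modest but real step in place of (furan-2-yl)carbonyl, whereas exchanging one aromatic group for another on the carbonyl carbon gave none beyond the scatter. No measurement at hand bears on the reason for this step.

The compounds shown do not separate the part played by the sulfonyl link from that of the 4-methylphenyl ring, and a 4-methylbenzoyl group or a methanesulfonyl group on the same nitrogen would pull the two apart. They also leave open whether the step carries over to the shorter chain of compound 1, and how a free amine at this nitrogen would read.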